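Benzyl to 4-methylphenyl swap on two cores

The source may report more compounds than this note shows. Statements on the series, on what has been measured and on what is new or still open speak of the compounds shown alone.

Measured in a functional assay on HCT-116 cells (Homo sapiens) for antiproliferative activity, read by MTT assay, with a stated time of 24 h; on this read-out higher numbers stand for weaker inhibition and lower numbers for stronger inhibition:
compound 1 `O=C1O/C(=C\Cn2cc(Cc3ccccc3)nn2)C(OCc2ccccc2)=C1OCc1ccccc1` gives 83100 nM
compound 2 `Cc1ccc(-c2cn(C/C=C3\OC(=O)C(OCc4ccccc4)=C3OCc3ccccc3)nn2)cc1` gives > 100000 nM, a limit of the assay
compound 3 `O=C1NC(O)(CCn2cc(Cc3ccccc3)nn2)C(OCc2ccccc2)=C1OCc1ccccc1` gives 51200 nM

Compound 1 and compound 2 differ by 4-methylphenyl in place of benzyl on an aromatic carbon. The step is an at least 1.2-fold higher number from compound 1 to compound 2 (0.08 log units; that floor lies within the scatter); how far past that floor it really goes is not known, because the limit of > 100000 nM in this assay, at which 1 of the 3 values shown sits, is all that the reading for compound 2 provides. Compound 3 has a different core from compound 1; the difference between the two cores is not broken down here. The gap between compound 3 and compound 1 in this assay lies within the scatter, so no order between them is drawn.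

Compound 4 `Cc1ccc(-c2cn(CCC3(O)NC(=O)C(OCc4ccccc4)=C3OCc3ccccc3)nn2)cc1` has not yet been measured in this assay. It stands to compound 3 as compound 2 stands to compound 1: 4-methylphenyl in place of benzyl on an aromatic carbon, the same change at the same place, on the core of compound 3 rather than that of compound 1. For the measured compounds named here, the only measured instance of this change does not fix a size, so the expectation rests on an at least 1.2-fold higher number from compound 1 to compound 2 (0.08 log units; that floor lies within the scatter). The starting point is compound 3 at 51200 nM. The expected step is a 1.8-fold higher number from compound 3 to compound 4 (0.24 log units; within the scatter), a weakening of uncertain size. Compound 4 is estimated at 90000 nM, expected to fall between 45000 nM and 250000 nM, with a real chance that only a limit is returned.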

Compound 4, half-maximal inhibitory concentration: 74300 nM
Estimate against measurement, compound 4: 1.2-fold (0.08 log units) above, and the stated range covers the measured number.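

In this assay, for the compounds shown here, 4-methylphenyl in place of benzyl on the second core gives a 1.5-fold higher number from compound 3 to compound 4 (0.16 log units; within the scatter), so this step alone sets no order for the pair. On the first core, compound 2 reads > 100000 nM, which is a limit of the assay and not a number. The two steps do not conflict, but they neither establish that the change carries from one core to the other nor give it a size, and a shared direction remains unproven: the same change on two cores in this assay, an at least 1.2-fold higher number (0.08 log units; that floor lies within the scatter) from compound 1 to compound 2 and a 1.5-fold higher number (0.16 log units; within the scatter) from compound 3 to compound 4; the limit leaves it open whether they differ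

The compounds shown leave open whether any other group on the five-membered aromatic ring with 3 nitrogen, such as a phenyl ring carrying an amine or a carboxylic acid, or a longer chain in place of benzyl, would move the number beyond the scatter on either core. They also leave open how far the reading depends on the two benzyloxy groups that all four compounds carry on the core, and whether replacing them with smaller methoxy groups would alter the comparison of the two cores.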